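Nitro in Place of Amino at the Aromatic Carbon

A few compounds are considered here, and "the series" means these few. Any claim that something is new, unique, unknown or untested is made for them only; others in the source may bear on it.

Compound 2 `COc1ccc(/C=C(/F)c2cc(OC)c(OC)c(OC)c2)cc1N` gives the lowest number of the three measured in a functional assay on HT-29 cells (Homo sapiens) for cytotoxicity, read by sulforhodamine B assay, with a stated time of 72 h (on this read-out higher numbers stand for weaker inhibition and lower numbers for stronger inhibition), at 2.9 nM. Compound 3 `COc1ccc(/C(F)=C\c2cc(OC)c(OC)c(OC)c2)cc1O` gives 28.9 nM in this assay, and compound 1 `COc1ccc(/C=C(/F)c2cc(OC)c(OC)c(OC)c2)cc1O` gives 100 nM. Among the measured compounds shown here, the only single-point step among the measured compounds is a 34-fold lower number from compound 1 to compound 2 (1.54 log units; beyond the scatter), a large gain on going from hydroxy to amino.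

Compound 4 `COc1ccc(/C=C(/F)c2cc(OC)c(OC)c(OC)c2)cc1[N+](=O)[O-]` differs from compound 2 by nitro in place of amino on an aromatic carbon. For the measured compounds named here, no measured pair sets nitro against amino, so the step has no direct precedent here. Going by the values given here, the one step at this aromatic carbon, a 34-fold lower number from compound 1 to compound 2 (1.54 log units; beyond the scatter), shows that the amino compound 2 stands well apart from the hydroxy compound 1 and that a change of this group can move the number a long way. Leaving the amino group is therefore expected to raise the number in this assay, with the expected step being a 17-fold higher number from compound 2 to compound 4 (1.24 log units; beyond the scatter), held with wide uncertainty. For compound 4 the estimate in this assay is 50 nM, within a range from 8 nM to 300 nM.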

Compound 4, half-maximal inhibitory concentration: 32 nM
Compound 4: the middle estimate sits 1.6-fold (0.19 log units) above what was measured; the range from low to high includes it.
By their numbers in this assay, from the lowest: compound 2; then compounds 3 and 4 (each within the scatter of the next); then compound 1.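

In this assay this aromatic carbon now carries three groups on the same core, and amino stands clearly apart: an 11-fold higher number from compound 2 to compound 4 (1.04 log units; beyond the scatter) shows that the large gain seen with a 34-fold lower number from compound 1 to compound 2 (1.54 log units; beyond the scatter) is not matched by any replacement of hydroxy. Nitro still improves on hydroxy, but only with a 3.1-fold lower number from compound 1 to compound 4 (0.49 log units; beyond the scatter), so the three groups run amino, nitro, hydroxy from the lowest number to the highest, with each step beyond the scatter. No measurement shown here accounts for this order.

Open, from the compounds shown here alone, is whether a methylamino group, an acetamide or a carboxylic acid at this carbon would come near the number of compound 2. Going by these compounds, the core of compound 3 appears only with hydroxy, so it remains open whether amino and nitro would keep this order there.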